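Methyl in Place of Fluoro: Cytotoxicity in Three Analogues

A few compounds are considered here, and "the series" means these few. Any claim that something is new, unique, unknown or untested is made for them only; others in the source may bear on it.

Compound 3 `N#Cc1ccc(Nc2nccc(Nc3ccc(-c4ccc(C#N)cc4)c(F)c3)n2)cc1` and compound 4 `Cc1cc(Nc2ccnc(Nc3ccc(C#N)cc3)n2)ccc1-c1ccc(C#N)cc1` are compared in a functional assay on MT4 cells (Homo sapiens) for cytotoxicity, read by MTT assay, with a stated time of 5 days; a lower number here means that less compound is tolerated, a higher number that more compound is tolerated. For compound 3 this assay gives only a limit, > 271000 nM. The change methyl in place of fluoro on an aromatic carbon is the same kind of change as methyl in place of fluoro on an aromatic carbon from compound 2 `N#Cc1ccc(Nc2nccc(Oc3ccc(-c4ccc(C#N)c(F)c4)cc3F)n2)cc1` to compound 1 `Cc1cc(-c2ccc(C#N)c(F)c2)ccc1Oc1ccnc(Nc2ccc(C#N)cc2)n1`, though the surroundings differ: in compound 4 the methyl sits ortho to a 4-cyanophenyl group and meta to a large group, whereas in compound 1 it sits ortho to a large group and meta to a 4-cyano-3-fluorophenyl group. How the core of compound 3 differs from that of compound 2 is not broken down here. In this assay compound 2 gives only a limit, > 294000 nM. Compound 1 likewise gives only a limit, > 296000 nM. The step that the two limits leave unreadable from compound 2 to compound 1 therefore cannot be sized, since the limit of > 294000 nM in this assay, at which 1 of the 3 values shown sits, and the limit of > 296000 nM in this assay, at which 1 of the 3 values shown sits, are both limits. The step to compound 4 is expected to be a step that the limit leaves unreadable from compound 3 to compound 4, resting on a step that the two limits leave unreadable from compound 2 to compound 1. Compound 4 is estimated at 300000 nM, most likely again only a limit.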

Compound 4, half-maximal cytotoxic concentration: 12400 nM
The estimate for compound 4 lay 24-fold (1.38 log units) above the measured number; measured number outside the range, below it.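

In this assay, methyl in place of fluoro on an aromatic carbon gives an at least 21-fold lower number from compound 3 to compound 4 (1.33 log units; beyond the scatter), so on the core of compound 3 this change clearly lowers the number. The same change on the core of compound 2 cannot be read, as compound 2 and compound 1 both give only limits, so nothing here tells whether the step carries from one core to the other. Within the data shown here, the single readable step shows that the change can matter, not that it does so generally or by a similar size on another core.

On these data alone, it remains open how a chloro group or a methoxy group on the same aromatic carbon of the core of compound 3 would read. Also open, as far as these compounds go, is whether a longer chain, such as ethyl, would take the number further in the same direction.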